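Chalcone-pyrazole series: methoxyphenyl for dichlorophenyl on the carbonyl

The compounds below may be only part of what the source reports. "The series", "measured", "known", "first", "only" and "open" are said of these compounds alone.

Two compounds of the series have numbers. In a functional assay on BT-549 cells (Homo sapiens) for cytotoxicity, read by sulforhodamine B assay, with a stated time of 48 h, tested at 1 uM (on this read-out lower numbers stand for a stronger effect and higher numbers for a weaker effect at the one concentration tested), compound 1 `COc1ccc(-c2cc(/C=C/C(=O)c3ccc(N)cc3)[nH]n2)cc1` gives 77%. In this assay, within the data shown here, compound 2 `COc1cc(-c2cc(/C=C/C(=O)c3ccc(Cl)c(Cl)c3)[nH]n2)cc(OC)c1OC` gives 92%, the highest of the two numbers and beyond that of compound 1 by a gap outside the usual scatter; the two compounds differ at more than one place, so no single step can be drawn between them.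

Compound 3 `COc1ccc(C(=O)/C=C/c2cc(-c3cc(OC)c(OC)c(OC)c3)n[nH]2)cc1` is not yet measured. Compared with compound 2 it carries 4-methoxyphenyl in place of 3,4-dichlorophenyl on a carbonyl carbon. Among the measured compounds shown here, no measured pair isolates this change, so its size can only be guessed. A step from compound 2 to compound 3 of a number 8 percentage points lower from compound 2 to compound 3 (within the scatter) is expected, modest and toward a lower number, but possibly none beyond the scatter. For compound 3 the estimate in this assay is 84%, within a range from 65% to 100%.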

Compound 3, a percentage reported as activity, at one concentration (the size of the read-out at that concentration, not a potency): 93%
Compound 3: the middle estimate sits 9 percentage points below what was measured, within the range that was stated.
By their numbers in this assay, from the lowest: compound 1; then compounds 2 and 3 (each within the scatter of the next).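

In this assay, among these compounds, the exchange at this position, 4-methoxyphenyl in place of 3,4-dichlorophenyl on a carbonyl carbon, gives a number 1 percentage points higher from compound 2 to compound 3 (within the scatter) and is the first step that isolates a single place. With the rest of compound 2 held fixed, the two aryl groups cannot be told apart at the one concentration tested, even though the chlorine atoms leave and a hydrogen-bond acceptor enters. On this one pair, the read-out does not separate the two groups, and one pair sets no trend for the position.

Going by these compounds, compound 1 differs from compound 2 and compound 3 at more than one place, so the source of its separate value remains open, as does the outcome with a carboxylic acid on this aryl ring. No supporting measurement bears on why this exchange gives the step it does.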